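A few compounds are considered here, and "the series" means these few. Any claim that something is new, unique, unknown or untested is made for them only; others in the source may bear on it.

Compound 1 `O=C1C(Nc2ccc(Br)cc2)=CC(=O)c2c1nc1n2[C@H]2OC[C@@H](O)[C@H]2OC1` gives 5220 nM in a functional assay on HeLa cells (Homo sapiens) for inhibition, read by sulforhodamine B assay (a lower number here means a stronger inhibitor, a higher number a weaker inhibitor), the higher of the two numbers measured in the set. Compound 2 `O=C1C=C(Nc2ccccc2F)C(=O)c2c1nc1n2[C@H]2OC[C@@H](O)[C@H]2OC1` gives 5120 nM in this assay, which sits within the scatter of compound 1. Compound 3 `O=C1C(N2CCC2)=CC(=O)c2c1nc1n2[C@H]2OC[C@@H](O)[C@H]2OC1` reaches only the limit of > 16000 nM in this assay and no number. Going by the values given here, the step of an at least 3.0-fold higher number from compound 1 to compound 3 (0.48 log units; beyond the scatter) is the one measured change in the set, and its size is known only from a limit (the limit of > 16000 nM in this assay, at which 1 of the 3 values shown sits).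

Compound 4 `CCCc1ccc(NC2=CC(=O)c3c(nc4n3[C@H]3OC[C@@H](O)[C@H]3OC4)C2=O)cc1` is not yet measured. It differs from compound 1 by propyl in place of bromo on an aromatic carbon. Among the compounds with values here, no measured step bears directly on this change: the only measured step replaces the whole arylamino group, whereas here the aryl ring stays and only its substituent changes. Within the data shown here, compound 2 carries a different aryl ring and differs from compound 1 in more than one place, so no step is counted for that pair; its two values sit within the scatter of each other. Among the measured compounds shown here, with no step of this kind to go on, the expectation is no change beyond the scatter in this assay. The estimate for compound 4 is 5000 nM, within 2000 nM to 13000 nM. The step this implies, a 1.0-fold lower number from compound 1 to compound 4 (0.02 log units; within the scatter), is expected to be small.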

Compound 4, half-maximal inhibitory concentration: 6030 nM
Beside the measured number, compound 4's estimate is 1.2-fold (0.08 log units) below it; low and high end bracket the measured number.
By their numbers in this assay, from the lowest: compounds 2, 1 and 4 (each within the scatter of the next). At a limit, above all of these: compound 3.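

In this assay, the aromatic carbon para to a large group takes propyl in place of bromo with no change beyond the scatter: a 1.2-fold higher number from compound 1 to compound 4 (0.06 log units; within the scatter). Going by these compounds alone, this is the first step that keeps the arylamino group and alters only the substituent on its ring, so the step that removes the whole (4-bromophenyl)amino group, an at least 3.0-fold higher number from compound 1 to compound 3 (0.48 log units; beyond the scatter), remains the only one beyond the scatter, and its size is known only from a limit. Nothing shown gives a cause for the absence of a change between the 4-bromophenyl and 4-propylphenyl compounds.

As far as these compounds go, whether this carbon behaves the same way with a carboxylic acid, an amine or a longer chain such as octyl remains open, as does whether any substituent there can move the number beyond the scatter in either direction. Compound 2 differs from compound 1 in more than one place, so the effect of moving a substituent to another carbon of the ring also remains unresolved.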